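The compounds below may be only part of what the source reports. "The series", "measured", "known", "first", "only" and "open" are said of these compounds alone.

Measured compounds:
compound 1, `CC(C(=O)NCc1ccc(C(F)(F)F)cc1N1CCCCCCC1)c1ccc(NS(C)(=O)=O)c(F)c1`, 2.8 nM
compound 2, `CCCCCCSc1cc(C(F)(F)F)ccc1CNC(=O)C(C)c1ccc(NS(C)(=O)=O)c(F)c1`, 1.8 nM
compound 3, `CC(C(=O)NCc1ccc(C(F)(F)F)cc1SC1CCCC1)c1ccc(NS(C)(=O)=O)c(F)c1`, 0.3 nM

In an assay on CHO cells for antagonist activity at transient receptor potential cation channel subfamily V member 1 (Homo sapiens), read by FLIPR (on this read-out lower numbers stand for stronger inhibition and higher numbers for weaker inhibition), compound 1 gives the highest of the three numbers. The step of a 1.6-fold lower number from compound 1 to compound 2 (0.19 log units; within the scatter) is within the scatter, while a 9.3-fold lower number from compound 1 to compound 3 (0.97 log units; beyond the scatter) is a modest gain and a 6.0-fold lower number from compound 2 to compound 3 (0.78 log units; beyond the scatter) points the same way.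

Compound 4, `CC(C(=O)NCc1ccc(C(F)(F)F)cc1Cl)c1ccc(NS(C)(=O)=O)c(F)c1`, carries one chlorine atom in place of a group of 8 heavy atoms (7 carbon, 1 nitrogen; one eight-membered non-aromatic ring with 1 hetero atom), on an aromatic carbon. Among the measured compounds shown here, no measured step replaces this group with a single atom; the two steps from compound 1 only show that a smaller group on this aromatic carbon gives an equal or lower number. The change to chloro is therefore expected to give at most a modest step, likely downward, a 1.9-fold lower number from compound 1 to compound 4 (0.27 log units; within the scatter). For compound 4 the estimate is 1.5 nM, in the range 0.4 nM to 6 nM.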

Compound 4, inhibition constant: 4 nM
The estimate for compound 4 lay 2.7-fold (0.43 log units) below the measured number; low and high end bracket the measured number.
By their numbers in this assay, from the lowest: compound 3; then compounds 2, 1 and 4 (each within the scatter of the next, the first and the last beyond it).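

In this assay, a single chlorine on this aromatic carbon reads like the eight-membered ring of compound 1 (a 1.4-fold higher number from compound 1 to compound 4 (0.15 log units; within the scatter)), so group size alone does not set the number here. Chloro falls short of both sulfur-linked groups, modestly against hexylsulfanyl (a 2.2-fold higher number from compound 2 to compound 4 (0.35 log units; beyond the scatter)) and by a large step against cyclopentylsulfanyl (a 13-fold higher number from compound 3 to compound 4 (1.12 log units; beyond the scatter)), which leaves compound 3 apart from the other three. No measurement at hand explains these steps.

Open, as far as these compounds go, is whether the lower number of compound 3 follows the sulfur link or the five-membered ring. A cyclopentyloxy or cyclopentylamino group on this carbon would separate the two.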